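Aryl swap on the ring amine nitrogen: outlook for compound 4

The source may hold more compounds than are shown below. What is called first, only, known or untested is meant among the compounds shown, and "the series" means these compounds.

Compound 1 `Nc1scc(CN2CCN(c3ccccc3C(F)(F)F)CC2)c1C(=O)c1ccc(Cl)cc1` is the reference of this small set. In a functional assay on CHO cells with adenosine receptor A1 (Homo sapiens) as the target, read by cAMP accumulation and immunoassay, with a stated time of 6 min, tested at 10 uM (on this read-out lower numbers stand for a stronger effect and higher numbers for a weaker effect at the one concentration tested), compound 1 gives -60%, the lowest of the three numbers measured and hence the strongest effect at the one concentration tested. Compound 2 `Nc1scc(CN2CCN(c3cccnc3)CC2)c1C(=O)c1ccc(Cl)cc1` gives -23% and compound 3 `Nc1scc(CN2CCN(c3cccc4ccccc34)CC2)c1C(=O)c1ccc(Cl)cc1` gives -21%; these two lie within the scatter of each other, as a number 2 percentage points higher from compound 2 to compound 3 (within the scatter) shows.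

Among the measured compounds shown here, two measured steps bear on the group carried by the amine nitrogen in the ring: a number 37 percentage points higher from compound 1 to compound 2 (beyond the scatter), and a number 39 percentage points higher from compound 1 to compound 3 (beyond the scatter). Each replacement of the 2-(trifluoromethyl)phenyl removes a large part of the effect, with pyridin-3-yl and naphthalen-1-yl ending at much the same number.

Compound 4 `Nc1scc(CN2CCN(c3c(F)cccc3F)CC2)c1C(=O)c1ccc(Cl)cc1` is not yet measured. It differs from compound 1 in one place: 2,6-difluorophenyl in place of 2-(trifluoromethyl)phenyl on an amine nitrogen in a ring. For the measured compounds named here, both relevant steps point the same way, a large weakening when 2-(trifluoromethyl)phenyl leaves, but no measured step tells how much of that loss is tied to the trifluoromethyl itself rather than to the carbon-only ring. A weakening step of moderate size, beyond the scatter yet smaller than the two measured ones, is therefore expected: a number 25 percentage points higher from compound 1 to compound 4 (beyond the scatter). For compound 4 the estimate is -35%, with a range from -60% to -10%.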

Compound 4, a percentage reported as activity, at one concentration (the size of the read-out at that concentration, not a potency): -80%
Compound 4: the middle estimate sits 45 percentage points above what was measured, and the stated range ends above it.
By their numbers in this assay, from the lowest: compound 4; then compound 1; then compounds 2 and 3 (each within the scatter of the next).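

In this assay the step of a number 20 percentage points lower from compound 1 to compound 4 (beyond the scatter) shows that 2-(trifluoromethyl)phenyl does not mark the upper end of the effect for the group on the amine nitrogen in a ring, as 2,6-difluorophenyl gives a stronger effect at the one concentration tested. Until now every measured change from compound 1 had weakened the effect, whereas the series now moves in both directions at this position, and the wider steps a number 59 percentage points lower from compound 3 to compound 4 (beyond the scatter) and a number 57 percentage points lower from compound 2 to compound 4 (beyond the scatter) show how much of the read-out depends on this one group while the rest of the compound stays fixed. No measurement at hand explains why these groups differ in this way.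

The compounds shown do not separate the contribution of each fluorine in 2,6-difluorophenyl from that of the two substituted positions taken together, a question that 2-fluorophenyl and 3-fluorophenyl would address. They also leave open whether 2,6-dichlorophenyl or 2,6-dimethylphenyl would give a read-out close to that of compound 4 or would fall back towards that of compound 1.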